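Taking the methoxy group off compound 3

The source may hold more compounds than are shown below. What is called first, only, known or untested is meant among the compounds shown, and "the series" means these compounds.

In a functional assay on Caco-2 cells (Homo sapiens) for inhibition, read by MTT assay, with a stated time of 48 h (on this read-out lower numbers stand for stronger inhibition and higher numbers for weaker inhibition), compound 3 `COc1ccccc1-c1csc(N/N=C/c2ccc(F)c(F)c2)n1` gives 25200 nM. Compound 1 `COc1cc(/C=N/Nc2nc(-c3ccc(Br)cc3)cs2)cc(Br)c1OC` gives 36200 nM in this assay, and these two numbers lie within the usual scatter of each other, so they cannot be ranked. Compound 2 `COc1cc(/C=N/Nc2nc(-c3ccc(C(F)(F)F)cc3)cs2)c(Br)c(Br)c1OC` gives no number at all, only a limit of the assay, > 100000 nM.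

Compound 4 `Fc1ccc(/C=N/Nc2nc(-c3ccccc3)cs2)cc1F` is compound 3 with one change: hydrogen in place of methoxy on an aromatic carbon, ortho to a large group (hydrogen in place of methoxy on an aromatic carbon). Cut one bond further out, the 2-methoxyphenyl becomes phenyl.

Going by the values given here, no two measured compounds here differ in one place only, so no measured step shows what this swap does in this assay. Without such a guide, the best starting point is the parent itself, and the expectation rests on compound 3 at 25200 nM. No shift beyond the scatter is expected, and the estimated change is small, a 1.2-fold higher number from compound 3 to compound 4 (0.08 log units; within the scatter). The direction of so small a change is uncertain, so the expected range is kept wide on both sides. Compound 4 is estimated at 30000 nM, with an expected range from 10000 nM to 90000 nM.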

Compound 4, half-maximal inhibitory concentration: 20900 nM
For compound 4 the middle estimate is 1.4-fold (0.16 log units) above the measured one, and the stated range covers the measured number.
By their numbers in this assay, from the lowest: compounds 4, 3 and 1 (each within the scatter of the next). At a limit, above all of these: compound 2.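

In this assay, going by these compounds alone, taking the methoxy group off gives a 1.2-fold lower number from compound 3 to compound 4 (0.08 log units; within the scatter), the first measured step here between compounds that differ in one place. At this position, on an aromatic carbon ortho to a large group, 2-methoxyphenyl and phenyl therefore cannot be told apart, so the methoxy group makes no measurable difference to the number on this read-out. Neither compound 3 nor compound 4 sits at the limit of the assay that compound 2 reaches, so this step is a comparison of two real numbers: the limit of > 100000 nM in this assay, at which 1 of the 4 values shown sits.

A single swap does not show how other groups would behave at this position, and an amine, a hydroxyl group or a longer chain such as ethoxy could still shift the number away from that of compound 4. It also leaves open whether hydrogen in place of methoxy would be as uneventful elsewhere, for instance at the methoxy groups on the other aromatic ring of compound 1, where the surroundings differ.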